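A few compounds are considered here, and "the series" means these few. Any claim that something is new, unique, unknown or untested is made for them only; others in the source may bear on it.

Three ureas have been measured in a functional assay on M21 cells (Homo sapiens) for antiproliferative activity, with a stated time of 48 h; a higher number here means a weaker inhibitor, a lower number a stronger inhibitor. Compound 1 `CC(C)(C)c1ccc(CNC(=O)NCCCCl)cc1` gives 11000 nM. Compound 3 `CCCCCc1cccc(NC(=O)NC(=O)CCl)c1` gives 3500 nM, a lower number than compound 1 by more than the scatter. Compound 2 `CCCCC(O)c1cccc(NC(=O)NCCCCl)c1` gives 35000 nM, a higher number than compound 1 by more than the scatter. Compound 1 therefore stands second highest of the three numbers, nearest to compound 3 and furthest from compound 2.

The next compound, compound 4 `CCNC(=O)NCc1ccc(C(C)(C)C)cc1`, has not yet been measured in this assay. It differs from compound 1 in one place: hydrogen in place of chloromethyl on a saturated chain carbon, two bonds along the chain from an amide-type nitrogen. Read one bond further out, the change is from 3-chloropropyl to ethyl on the urea nitrogen. Within the data shown here, no measured pair shows this change directly, so its effect can only be guessed. Among the measured compounds shown here, the two lowest numbers so far, from compound 3 and compound 1, both belong to compounds that carry a chlorine on the chain, and compound 4 carries none. On that slim basis a weaker inhibitor is expected. The step from compound 1 to compound 4 in this assay is expected to be a 3.2-fold higher number from compound 1 to compound 4 (0.50 log units; beyond the scatter), an increase beyond the scatter. Compound 4 is expected to give about 35000 nM, within a range from 10000 nM to 120000 nM.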

Compound 4, half-maximal inhibitory concentration: > 100000 nM
Compound 4: no number, only a limit; the forecaster's own chance of this, stated with the estimate: 30%; at least 2.8-fold (0.45 log units) between middle value and limit.
By their numbers in this assay, from the lowest: compound 3; then compound 1; then compound 2. At a limit, above all of these: compound 4.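

In this assay compound 4 gives > 100000 nM, which is a limit of the assay and not a number. Among these compounds, this is the first pair that differs in one place, and it gives a direct reading of the change, an at least 9.0-fold higher number from compound 1 to compound 4 (0.95 log units; beyond the scatter): with hydrogen in place of chloromethyl on a saturated chain carbon, two bonds along the chain from an amide-type nitrogen, which turns 3-chloropropyl into ethyl on the urea nitrogen, the compound is a clearly weaker inhibitor. The direction of this step is therefore firm, but its true size remains unknown, and only the one compound sits at the limit: the limit of > 100000 nM in this assay, at which 1 of the 4 values shown sits.

This single change removes both the chlorine and part of the chain, so the pair cannot say which of the two matters, and a plain propyl or a 3-fluoropropyl group on the same urea nitrogen would be needed to tell them apart. As far as these compounds go, compound 2 and compound 3 each differ from compound 1 in more than one place, so steps to them cannot be read, and the effect of the chlorine in the other cores remains open.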